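Replacing 3,5-dimethylphenyl with 4-nitrophenyl in compound 2

The source may report more compounds than this note shows. Statements on the series, on what has been measured and on what is new or still open speak of the compounds shown alone.

Measured in a functional assay on HL-60 cells (Homo sapiens) for inhibition, read by CCK-8 assay, with a stated time of 48 h; on this read-out higher numbers stand for weaker inhibition and lower numbers for stronger inhibition:
Compound 1 `COc1ccc(Oc2ccc(C(C)C)cc2-c2ccsc2S(=O)(=O)NCCNC(=S)Nc2ccc([N+](=O)[O-])cc2)cc1OC`: 11200 nM
Compound 2 `Cc1cc(C)cc(NC(=O)NCCNS(=O)(=O)c2ccc(-c3ccccc3Oc3ccc([N+](=O)[O-])c([N+](=O)[O-])c3)s2)c1`: 9100 nM

In this assay compound 2 gives 9100 nM, which lies within the scatter of compound 1 at 11200 nM. The two compounds therefore cannot be ranked on these numbers. Compound 3 `O=C(NCCNS(=O)(=O)c1ccc(-c2ccccc2Oc2ccc([N+](=O)[O-])c([N+](=O)[O-])c2)s1)Nc1ccc([N+](=O)[O-])cc1` has not yet been measured. It carries 4-nitrophenyl in place of the 3,5-dimethylphenyl of compound 2 on an amide-type nitrogen (4-nitrophenyl in place of 3,5-dimethylphenyl on an amide-type nitrogen). For the measured compounds named here, no measured pair differs in one place, so the data offer no direct guide to this change. Compound 1 also carries a 4-nitrophenyl group and gives 11200 nM, so no step beyond the scatter is expected in this assay, and no direction is favoured. The estimate amounts to an expected 1.0-fold lower number from compound 2 to compound 3 (0.00 log units; within the scatter). For compound 3 the estimated value is 9000 nM, with an expected range of 3500 nM to 22000 nM.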

Compound 3, half-maximal inhibitory concentration: 340 nM
Compound 3: middle estimate off by 26-fold (1.42 log units), on the high side; the whole stated range lies above it.
By their numbers in this assay, from the lowest: compound 3; then compounds 2 and 1 (each within the scatter of the next).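

In this assay the group on the amide-type nitrogen proves to matter: 4-nitrophenyl in place of 3,5-dimethylphenyl gives a 27-fold lower number from compound 2 to compound 3 (1.43 log units; beyond the scatter) and so lies well beyond the scatter. The earlier compounds shown here differ from each other in more than one place and could not isolate this position, whereas this single change shows that the number responds strongly to the group held there while the rest of compound 2 stays the same. No measurement at hand bears on what lies behind this step.

This one exchange does not separate the arrival of the nitro group from the loss of the two methyl groups. Going by these compounds, whether an unsubstituted phenyl or a 4-aminophenyl at the same place would keep the lower number remains open, as does whether the step would recur on another core.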